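Swapping the aniline for a fluoropyridine amine

The source may hold more compounds than are shown below. What is called first, only, known or untested is meant among the compounds shown, and "the series" means these compounds.

Compound 1 `CCS(=O)(=O)Nc1cc(-c2ccc3ncnc(Nc4ccc(OC(F)(F)F)cc4)c3c2)cnc1OC` gives 22400 nM in a functional assay on SNU-638 cells (Homo sapiens) for cytotoxicity, read by sulforhodamine B assay, with a stated time of 72 h; a lower number here means a stronger inhibitor, a higher number a weaker inhibitor.
Compound 2 `CCS(=O)(=O)Nc1cc(-c2ccc3ncnc(Nc4ccc(Cl)c(C(=O)OC)c4)c3c2)cnc1OC` gives 2200 nM in this assay.

Going by the values given here, of the two numbers measured so far in this assay, compound 2 holds the lowest; the only comparison available is the step of a 10-fold lower number from compound 1 to compound 2 (1.01 log units; beyond the scatter), which shows that the group on the nitrogen on an aromatic ring can shift the result a great deal. Compound 3 `CCS(=O)(=O)Nc1cc(-c2ccc3ncnc(Nc4ccc(F)nc4)c3c2)cnc1OC` carries 6-fluoropyridin-3-yl in place of 4-chloro-3-(methoxycarbonyl)phenyl on a nitrogen on an aromatic ring. Among the compounds with values here, no measured step covers this particular exchange, so the one known step serves only as a warning that changes in this place can be large in either direction. The group that carried compound 2 to its 2200 nM is removed, and nothing in the data shows that the smaller ring will make up for it. Compound 3 is therefore expected to land at 8000 nM, within a range from 2000 nM to 30000 nM. That estimate corresponds to an expected 3.6-fold higher number from compound 2 to compound 3 (0.56 log units; beyond the scatter).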

Compound 3, half-maximal inhibitory concentration: 6520 nM
The estimate for compound 3 lay 1.2-fold (0.09 log units) above the measured number; the measured number falls inside the stated range.
By their numbers in this assay, from the lowest: compound 2; then compound 3; then compound 1.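

In this assay, replacing the larger group of compound 2 with 6-fluoropyridin-3-yl gives a 3.0-fold higher number from compound 2 to compound 3 (0.47 log units; beyond the scatter) and yet replacing the 4-(trifluoromethoxy)phenyl group gives a 3.4-fold lower number from compound 1 to compound 3 (0.54 log units; beyond the scatter) so the new group ranks in the middle of the three. This shows that a ring containing a hetero atom can sit on this nitrogen without giving the highest number, and that neither the chlorine nor the methoxycarbonyl group is needed to beat compound 1. Nothing available explains this order.

The compounds shown cannot separate the effect of the fluorine from that of the ring nitrogen. On these data alone, it also remains open whether a carboxylic acid or an amine in place of the methoxycarbonyl group in 4-chloro-3-(methoxycarbonyl)phenyl would lower the number further.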